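The source may report more compounds than this note shows. Statements on the series, on what has been measured and on what is new or still open speak of the compounds shown alone.

Of the compounds shown here, three built on the shared core have already been measured. Compound 1 `CCc1cc(Br)ccc1S(=O)(=O)N1CCC(N2CCC(C)CC2)CC1`, compound 2 `Cc1cc(C)c(S(=O)(=O)N2CCC(N3CCC(C(C)C)CC3)CC2)c(C)c1` and compound 3 `Cc1cc(S(=O)(=O)N2CCC(N3CCC(C)CC3)CC2)c(Cl)cc1Cl` were each tested in a functional assay on HT-29 cells (Homo sapiens) for antiproliferative activity, read by CellTiter-Glo, with a stated time of 72 h; a lower number here means a stronger inhibitor, a higher number a weaker inhibitor. In this assay compound 1 gives 0.5 nM, compound 2 gives 0.2 nM and compound 3 gives 1.1 nM. Compound 2 therefore stands at the lowest number of the three, and its distance to each of the other two is wider than the usual scatter, so among these three compound 2 is the strongest inhibitor.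

Compound 4 `Cc1cc(C)c(S(=O)(=O)N2CCC(N3CCC(Cc4ccccc4)CC3)CC2)c(C)c1` has not yet been measured. It differs from compound 2 in a single place: benzyl in place of isopropyl on a saturated ring carbon. Going by the values given here, no measured pair changes this position in a comparable way, so the size of the step cannot be read off from earlier data; the three measured numbers all sit close together, which gives no sign that this part of the molecule swings the result widely. The expected step is a 2.5-fold higher number from compound 2 to compound 4 (0.40 log units; beyond the scatter), that is, a small move whose direction is uncertain and which may well lie within the scatter. For compound 4 the estimated value in this assay is 0.5 nM, with a likely range from 0.1 nM to 3 nM.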

Compound 4, half-maximal inhibitory concentration: 3 nM
Compound 4: middle estimate off by 6.0-fold (0.78 log units), on the low side, and the stated range covers the measured number.
By their numbers in this assay, from the lowest: compound 2; then compound 1; then compound 3; then compound 4.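

Placing benzyl in place of isopropyl on a saturated ring carbon gives in this assay a 15-fold higher number from compound 2 to compound 4 (1.18 log units; beyond the scatter), a large step beyond the scatter. Going by these compounds alone, this is the first direct reading of this position, and it shows that the group carried here matters clearly, although compound 4 stays active at 3 nM with seven carbons and an aromatic ring in the place of three carbons and no ring. Nothing among the data given explains why this change weakens the compound.

The compounds shown leave open whether the step follows the aromatic ring itself or simply the added carbons, a question that cyclohexylmethyl on the same ring carbon could help to separate, since it keeps a six-membered ring but has no aromatic one. Also open, on these data alone, is how this position would respond to a group that brings in atoms other than carbon, such as an aminomethyl or a carboxylic acid, and whether smaller groups such as ethyl would sit nearer to compound 2 or to compound 4.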